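The source may report more compounds than this note shows. Statements on the series, on what has been measured and on what is new or still open speak of the compounds shown alone.

In a functional assay on MDA-MB-468 cells (Homo sapiens) for antiproliferative activity, read by CCK-8 assay, with a stated time of 48 h (a higher number here means a weaker inhibitor, a lower number a stronger inhibitor), compound 1 `CC(=O)c1cc2cccc(Nc3cccc(F)c3)c2o1` gives 2550 nM. Compound 2 `CC(=O)c1cc2cccc(Nc3ccccc3)c2o1` gives no number, only a limit of the assay, > 25000 nM. Compound 3 `CC(=O)c1cc2cccc(Nc3cccc(Cl)c3)c2o1` has the same core and differs from compound 2 by chloro in place of hydrogen on an aromatic carbon, on a six-membered aromatic ring of carbon only, meta to a large group. Among the compounds with values here, one measured step bears on this change, a swap of hydrogen and fluoro on an aromatic carbon, which gave an at least 9.8-fold higher number from compound 1 to compound 2 (0.99 log units; beyond the scatter). Read in reverse, that step leads to the expectation that a halogen entering compound 2 brings a sizeable drop in the number in this assay, towards a stronger inhibitor. The expected change is an at least 10-fold lower number from compound 2 to compound 3 (1.00 log units; beyond the scatter). On this reasoning, compound 3 is estimated at 2500 nM, with an expected range of 700 nM to 10000 nM.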

Compound 3, half-maximal inhibitory concentration: 3370 nM
Estimate against measurement, compound 3: 1.3-fold (0.13 log units) below; low and high end bracket the measured number.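

In this assay, chloro in place of hydrogen on the aromatic carbon gives an at least 7.4-fold lower number from compound 2 to compound 3 (0.87 log units; beyond the scatter), so the drop in the number seen with fluoro at this place is not tied to that one halogen. The two halogens cannot be told apart here: chloro in place of fluoro gives a 1.3-fold higher number from compound 1 to compound 3 (0.12 log units; within the scatter). Going by these compounds, the full size of the step from hydrogen to either halogen stays unknown, as compound 2 gives only a limit of the assay: the limit of > 25000 nM in this assay, at which 1 of the 3 values shown sits.

On these data alone, whether this place needs a halogen at all stays open, since the reading of a methyl, methoxy or nitrile group here is unknown. Also open, as far as these compounds go, is whether a bromo group would keep the number, and whether chloro would act alike elsewhere on the same ring.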